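Adding a Second Nitro Group to Compound 3

The compounds below may be only part of what the source reports. "The series", "measured", "known", "first", "only" and "open" are said of these compounds alone.

Compound 3 `O=c1cc(/C=N\Nc2ccc([N+](=O)[O-])cc2)c2c(OCc3ccccc3)cc(OCc3ccccc3)cc2o1` stands second highest of the three numbers measured in a functional assay, read by spectrophotometry, with a stated time of 3 min (a lower number here means a stronger inhibitor, a higher number a weaker inhibitor), where compound 3 gives 15500 nM. Among the compounds with values here, compound 1 `O=c1cc(/C=N\O)c2c(OCc3ccccc3)cc(OCc3ccccc3)cc2o1` gives 38700 nM, and the step of a 2.5-fold lower number from compound 1 to compound 3 (0.40 log units; beyond the scatter) is the only one-place step known here, a modest one. Compound 2 `O=c1cc(/C=N\Nc2ccc([N+](=O)[O-])cc2[N+](=O)[O-])c2ccc(OCc3ccccc3)cc2o1` gives 6490 nM; it differs from compound 3 in two places, so the two values can only be set side by side, and they show a lower number for compound 2 than for compound 3.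

Compound 4 `O=c1cc(/C=N\Nc2ccc([N+](=O)[O-])cc2[N+](=O)[O-])c2c(OCc3ccccc3)cc(OCc3ccccc3)cc2o1` arises from compound 3 by the change (nitro in place of hydrogen on an aromatic carbon). Within the data shown here, no measured step isolates this change. The step from compound 1 to compound 3 concerns another position and only sets the scale of effects seen so far as modest. As far as these compounds go, compound 2, which carries the 2,4-dinitrophenyl group, has a lower number than compound 3, but compound 2 also differs from compound 3 at a second place on the shared core, so how much of that gap belongs to the nitro group stays open. Compound 4 is therefore expected to show a modest step of a 1.7-fold lower number from compound 3 to compound 4 (0.24 log units; within the scatter) toward a lower number. The estimate for compound 4 is 9000 nM, expected to fall between 4000 nM and 25000 nM.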

Compound 4, half-maximal inhibitory concentration: "not active" (no number reported)
Nothing numeric was reported for compound 4, and the estimate cannot be compared.
By their numbers in this assay, from the lowest: compound 2; then compound 3; then compound 1.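

Within the data shown here, compound 4 was reported as "not active" in this assay, with no number, so no step from compound 3 to compound 4 can be read. The compounds shown leave open how far 2,4-dinitrophenyl in place of 4-nitrophenyl shifts the number on the shared core. No evidence available here bears on this result.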